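Working notes: swapping the ring on the carbonyl carbon

The source may hold more compounds than are shown below. What is called first, only, known or untested is meant among the compounds shown, and "the series" means these compounds.

Compound 2 `COc1ccc(C(=O)/C=C/c2cc(-c3cc(OC)c(OC)c(OC)c3)n[nH]2)cc1OC` carries a 3,4-dimethoxyphenyl on the carbonyl carbon. In a functional assay on 786-0 cells (Homo sapiens) for inhibition, read by sulforhodamine B assay, with a stated time of 48 h (a lower number here means that less compound is tolerated, a higher number that more compound is tolerated), compound 2 gives 5820 nM. Within the data shown here, it is the only compound of the pair with a number, the other value being a limit. Compound 1 `COc1cc(-c2cc(/C=C/C(=O)c3ccc(Cl)c(Cl)c3)[nH]n2)cc(OC)c1OC`, with 3,4-dichlorophenyl in that position, reaches only the limit of this assay, > 100000 nM. Among the measured compounds shown here, the one measured step, an at least 17-fold lower number from compound 1 to compound 2 (1.23 log units; beyond the scatter), is itself only a floor since it rests on (the limit of > 100000 nM in this assay, at which 1 of the 2 values shown sits).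

Compound 3 `COc1cc(-c2cc(/C=C/C(=O)c3ccc(F)c(F)c3)[nH]n2)cc(OC)c1OC` is the next member: 3,4-difluorophenyl in place of 3,4-dimethoxyphenyl on a carbonyl carbon. This reverses the direction of the measured step, returning from a dimethoxy ring to a dihalogenated ring on the carbonyl carbon, so the change in this assay is expected to run opposite to the step from compound 1 to compound 2 and to be large. The estimated step is a 6.9-fold higher number from compound 2 to compound 3 (0.84 log units; beyond the scatter), and there is a real chance that compound 3, like compound 1, returns only a limit. The expected value for compound 3 is 40000 nM, within a range from 8000 nM to 200000 nM.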

Compound 3, concentration lethal to 50% of the cells: > 100000 nM
Compound 3: a limit, no number; the forecaster's own chance of this, stated with the estimate: 40%; middle value at least 2.5-fold (0.39 log units) from the limit.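

The change back to a dihalogenated ring gives an at least 17-fold higher number from compound 2 to compound 3 (1.23 log units; beyond the scatter) and this step, like the earlier one, is only a floor. Compound 2, with 3,4-dimethoxyphenyl on the carbonyl carbon, now stands apart from two dihalogenated partners rather than one, so in this assay the end at the limit is not confined to the 3,4-dichlorophenyl ring but also holds for 3,4-difluorophenyl, while the only number shown still belongs to the dimethoxy ring. The step between compound 1 and compound 3 cannot be read, so the two halogen pairs cannot be placed in any order, and the size of the gap to compound 2 remains unknown on both sides: the limit of > 100000 nM in this assay, at which 2 of the 3 values shown sit.

The compounds shown leave open whether a number in this assay depends on the methoxy groups as a pair, or whether a plain phenyl, a methoxyphenyl or a hydroxyphenyl ring on the carbonyl carbon would also give one. They also leave open whether a dimethylaminophenyl ring in this position would fall on the side of compound 2 or on that of the dihalogenated compounds.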